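The compounds below may be only part of what the source reports. "The series", "measured", "known", "first", "only" and "open" are said of these compounds alone.

Measured so far in a physicochemical assay for solubility, in phosphate buffer, at pH 7.4; on this read-out higher numbers stand for higher solubility and lower numbers for lower solubility:
- compound 1 `CC1(C)[C@H]2CC[C@]1(C)C(NC(=O)Nc1ccccc1F)C2`: 225000 nM
- compound 2 `CCOC(=O)CNC(=O)NC1CC2CCC1(C)C2(C)C`: > 2000000 nM
- compound 3 `CC1(C)[C@@H]2CC[C@@]1(C)C(NC(=O)Nc1ccccc1F)C2`: 225000 nM

Compound 2 stands at > 2000000 nM, which is a limit of the assay and not a number. It therefore gives no exact starting point for the next step.

Compound 4 `CCCCCCCCNC(=O)NC1CC2CCC1(C)C2(C)C` is not yet measured. It carries heptyl in place of ethoxycarbonyl on a saturated chain carbon bound to an amide-type nitrogen.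

For the measured compounds named here, the only measured step, no change at the digits printed from compound 1 to compound 3 (within the scatter), concerns the fact that one of compounds 1 and 3 is drawn with a defined configuration and the other without, at the place where they differ and says nothing directly about this chain change. Only indirect guidance remains. Compound 1 has no ethoxycarbonyl and gives 225000 nM, and compound 3, also without it, gives 225000 nM. Compound 4 also lacks that group, so it is expected to read lower in this assay than the limit of its parent, probably under the level of these two.

A clear downward move beyond the scatter is expected, with an estimated at least 40-fold lower number from compound 2 to compound 4 (1.60 log units; beyond the scatter). For compound 4 the estimate is 50000 nM, with an expected range from 10000 nM to 220000 nM.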

Compound 4, solubility: 125000 nM
Beside the measured number, compound 4's estimate is 2.5-fold (0.40 log units) below it; measured number inside the range.
By their numbers in this assay, from the lowest: compounds 4, 1 and 3 (each within the scatter of the next). At a limit, above all of these: compound 2.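

Compound 2 stands at > 2000000 nM, which is a limit of the assay and not a number. For the compounds shown here, on a saturated chain carbon bound to an amide-type nitrogen, heptyl in place of ethoxycarbonyl gives the first step beyond the scatter in this assay, namely an at least 16-fold lower number from compound 2 to compound 4 (1.20 log units; beyond the scatter), whereas the earlier step between compounds 1 and 3 concerned only drawn configuration and showed no change. The change at this position therefore moves the read-out, but its full size stays unread: the limit of > 2000000 nM in this assay, at which 1 of the 4 values shown sits.

On these data alone, this rests on a single pair of compounds, so it remains open whether losing ethoxycarbonyl or gaining heptyl carries the step. A butyl chain, a carboxylic acid or an amine at the same place would help separate the two and show whether the read-out follows chain length.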